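Removing the exocyclic amino from the core of compound 1

This account rests on a few compounds, and the source may have more. Where it says the series, first, only, none or still open, it means among the compounds named here.

Within the data shown here, compound 1 `CCN1CCN(CCCn2cnc3c(N4CCN(CC)CC4)nc(N)nc32)CC1` stands at the lowest of the three numbers so far recorded in an assay on HEK293 cells for antagonist activity at Toll-like receptor 9 (Homo sapiens), read by spectrophotometry (on this read-out higher numbers stand for weaker inhibition and lower numbers for stronger inhibition), where compound 1 gives 260 nM. Compound 2 `CCN1CCN(CCCn2cnc3c(N4CCN(CC)CC4)nc(N4CCCC4)nc32)CC1` gives 500 nM in this assay, and the single-point step is a 1.9-fold higher number from compound 1 to compound 2 (0.28 log units; within the scatter), pyrrolidin-1-yl in place of amino on an aromatic carbon. Compound 3 `CCN1CCN(CCCn2cnc3c(N4CCN(C(=O)C5CCCC5)CC4)nc(NCc4ccc(N(CC)CC)cc4)nc32)CC1` differs in more than one place from the other two; in this assay compound 3 gives 8800 nM, and it shows only how far the numbers in this series can rise, without a single step to compare.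

Compound 4 `CCN1CCN(CCCn2cnc3c(N4CCN(CC)CC4)ncnc32)CC1` is the next single-point change from compound 1: hydrogen in place of amino on an aromatic carbon. Among the measured compounds shown here, the one step that bears on it is the one from compound 1 to compound 2, which also altered the amino at that aromatic carbon and stayed within the scatter. It bears only loosely, since there the amino was replaced by a ring and here by a hydrogen; nothing measured shows the bare carbon. The expectation for compound 4 in this assay is therefore a small step toward a higher number, a 1.9-fold higher number from compound 1 to compound 4 (0.28 log units; within the scatter), quite possibly within the scatter. Compound 4 is expected at 500 nM, with a range from 200 nM to 1500 nM.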

Compound 4, half-maximal inhibitory concentration: 1190 nM
For compound 4 the middle estimate is 2.4-fold (0.38 log units) below the measured one; the measured number falls inside the stated range.
By their numbers in this assay, from the lowest: compounds 1 and 2 (each within the scatter of the next); then compound 4; then compound 3.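

Among these compounds, on the aromatic carbon between two ring nitrogen atoms, a bare hydrogen is the first change to move the number beyond the scatter in this assay: removing the amino gives a 4.6-fold higher number from compound 1 to compound 4 (0.66 log units; beyond the scatter), and removing the pyrrolidin-1-yl gives a 2.4-fold higher number from compound 2 to compound 4 (0.38 log units; beyond the scatter), both modest steps. Exchanging one group for the other gave only a 1.9-fold higher number from compound 1 to compound 2 (0.28 log units; within the scatter), so among these three compounds the position tolerates amino or pyrrolidin-1-yl without a readable difference, while compound 4, with neither group, stands apart from both. Nothing available explains why the loss of either group raises the number.

From the compounds shown here alone, it remains open whether any substituent on this carbon would serve or only a group attached through nitrogen, which a methyl, a methoxy or a chlorine at the same place would help to separate. Also open, going by these compounds, is whether the same steps would hold with another amine, such as a morpholine, in place of the 4-ethylpiperazin-1-yl group.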